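The compounds below may be only part of what the source reports. "The series", "measured", "known", "first", "only" and "open" are said of these compounds alone.

Among the compounds with values here, compound 1 `COC(=O)/C(=C\c1ccc(OC(=O)c2cc(OC)cc(OC)c2)cc1)Sc1ccnc2cc(Cl)ccc12` gives 28900 nM in a functional assay on Jurkat E6.1 cells (Homo sapiens) for cytotoxicity, read by MTT assay, with a stated time of 24 h (a lower number here means a stronger inhibitor, a higher number a weaker inhibitor), the highest of the three numbers measured so far. Compound 2 `COC(=O)/C(=C\c1ccc(OC(=O)c2ccc(OC)cc2OC)cc1)Sc1ccnc2cc(Cl)ccc12` gives 10200 nM and compound 3 `COC(=O)/C(=C\c1ccc(OC(=O)c2cc(OC)c(OC)cc2OC)cc1)Sc1ccnc2cc(Cl)ccc12` gives 9650 nM. Both changes of the aryl on the carbonyl carbon lowered the number: a 2.8-fold lower number from compound 1 to compound 2 (0.45 log units; beyond the scatter) and a 3.0-fold lower number from compound 1 to compound 3 (0.48 log units; beyond the scatter); between those two, a 1.1-fold lower number from compound 2 to compound 3 (0.02 log units; within the scatter). Compound 4 `COC(=O)/C(=C\c1ccc(OC(=O)c2ccc(OC)c(OC)c2OC)cc1)Sc1ccnc2cc(Cl)ccc12` differs from compound 1 by 2,3,4-trimethoxyphenyl in place of 3,5-dimethoxyphenyl on a carbonyl carbon. The two measured steps from compound 1 bear on this change, since each swapped the 3,5-dimethoxyphenyl for a differently substituted methoxyphenyl and each lowered the number modestly. A similar modest lowering is therefore expected for compound 4, about a 2.6-fold lower number from compound 1 to compound 4 (0.42 log units; beyond the scatter). Compound 4 is estimated at 11000 nM, with a range from 4500 nM to 27000 nM.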

Compound 4, half-maximal inhibitory concentration: 2410 nM
Beside the measured number, compound 4's estimate is 4.6-fold (0.66 log units) above it, outside the stated range (below it).
By their numbers in this assay, from the lowest: compound 4; then compounds 3 and 2 (each within the scatter of the next); then compound 1.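

With a 12-fold lower number from compound 1 to compound 4 (1.08 log units; beyond the scatter) the 2,3,4-trimethoxyphenyl on the carbonyl carbon goes well past the earlier aryl changes. A methoxy in place of hydrogen gives a 4.2-fold lower number from compound 2 to compound 4 (0.63 log units; beyond the scatter) here, while the one leading to compound 3 gave a 1.1-fold lower number from compound 2 to compound 3 (0.02 log units; within the scatter) so among these compounds the place of the added methoxy counts, not its presence alone. The two trimethoxyphenyl groups also part, with a 4.0-fold lower number from compound 3 to compound 4 (0.60 log units; beyond the scatter) on the same core.

Nothing at hand explains this difference. From the compounds shown here alone, whether a hydroxy or an amine in place of a methoxy on this aryl would keep the lower number stays open.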